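Adding a Methoxy Group to the Core of Compound 1

The compounds below may be only part of what the source reports. "The series", "measured", "known", "first", "only" and "open" are said of these compounds alone.

Measured so far:
compound 1, `O=c1oc(-c2ccccc2I)nc2ccccc12`, gives 16700 nM in an assay on isolated protein for inhibition of complement C1r subcomponent (Homo sapiens); on this read-out lower numbers stand for stronger inhibition and higher numbers for weaker inhibition
compound 2, `COc1ccccc1-c1nc2ccccc2c(=O)o1`, reaches only a limit of this assay, > 62500 nM
compound 3, `O=c1oc(-c2ccccc2I)nc2cccc(Cl)c12`, gives 13500 nM in this assay

Compound 1 gives the highest of the two numbers shown; compound 3 is nearest, with a 1.2-fold lower number from compound 1 to compound 3 (0.09 log units; within the scatter). For compound 2 this assay reports only a limit, (the limit of > 62500 nM in this assay, at which 1 of the 3 values shown sits).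

Compound 4, `COc1ccc2c(=O)oc(-c3ccccc3I)nc2c1`, differs from compound 1 by methoxy in place of hydrogen on an aromatic carbon. Among the compounds with values here, two measured steps bear on it. The first, a 1.2-fold lower number from compound 1 to compound 3 (0.09 log units; within the scatter), is a small group placed on the same fused ring of the core. The second, an at least 3.7-fold higher number from compound 1 to compound 2 (0.57 log units; beyond the scatter), puts a methoxy elsewhere while removing the iodo, which compound 4 keeps, so it speaks less directly. No step beyond the scatter is therefore expected for compound 4, that is a 1.1-fold lower number from compound 1 to compound 4 (0.05 log units; within the scatter). Compound 4 is estimated at 15000 nM, expected between 6000 nM and 40000 nM.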

Compound 4, half-maximal inhibitory concentration: > 62500 nM
Compound 4: a limit, no number (the forecaster's own chance of this, stated with the estimate: 15%); middle value at least 4.1-fold (0.61 log units) away from the limit.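

On the core of compound 1, methoxy in place of hydrogen on this aromatic carbon, meta to a fused ring and para to a fused ring, gives in this assay an at least 3.7-fold higher number from compound 1 to compound 4 (0.57 log units; beyond the scatter). Compound 4 keeps the iodo, so the iodo alone does not preserve the inhibition seen for compound 1. Compound 4 gives only a limit, so the full size of the step stays unknown and the read-out cannot separate it from compound 2: the limit of > 62500 nM in this assay, at which 2 of the 4 values shown sit.

Still open, on these data alone, is whether a fluoro, a hydroxy or an amine on this carbon would behave as the methoxy does. Also open, as far as these compounds go, is whether the step belongs to methoxy specifically or to substitution at this place generally.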